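A Smaller Group on the Chain of Compound 2

The source may report more compounds than this note shows. Statements on the series, on what has been measured and on what is new or still open speak of the compounds shown alone.

In a functional assay on SK-BR-3 cells (Homo sapiens) for cytotoxicity, read by MTT assay, with a stated time of 72 h (on this read-out lower numbers stand for stronger inhibition and higher numbers for weaker inhibition), compound 1 (`Nc1cccc(Nc2c(C(=O)NCc3ccc(F)cc3)nc(Br)c3cccnc23)c1`) gives > 10000 nM and this is a limit of the assay and not a number. Among the compounds with values here, compound 2 (`O=C(NCCCNc1c(C(=O)NCc2ccc(F)cc2)nc(Br)c2cccnc12)c1ccccc1`) gives 1000 nM as the only numerical value so far. Compound 3 (`COC(=O)CNc1c(C(=O)NCc2ccc(F)cc2)nc(Br)c2cccnc12`) carries methoxycarbonyl in place of 2-benzamidoethyl on a saturated chain carbon bound to a nitrogen on an aromatic ring. Within the data shown here, no pair of measured compounds isolates this change, so the expectation remains tentative. Against compound 2 with 1000 nM as the reference, a moderate weakening is expected in this assay and the estimated change is a 4.0-fold higher number from compound 2 to compound 3 (0.60 log units; beyond the scatter) on this reckoning. Compound 3 is estimated at 4000 nM with an expected range from 1200 nM to 14000 nM in this assay once it is read.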

Compound 3, half-maximal inhibitory concentration: 1000 nM
Estimate against measurement, compound 3: 4.0-fold (0.60 log units) above, and the stated range ends above it.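

Putting methoxycarbonyl in place of 2-benzamidoethyl on a saturated chain carbon bound to a nitrogen on an aromatic ring gives no change at the digits printed from compound 2 to compound 3 (within the scatter) in this assay, so here the read-out does not depend on the six-membered aromatic ring or the 11 heavy atoms of the group that leaves. Putting (methoxycarbonyl)methyl in place of 3-aminophenyl on a nitrogen on an aromatic ring gives an at least 10-fold lower number from compound 1 to compound 3 (1.00 log units; beyond the scatter). The value of compound 1 is a limit of the assay and not a number, so this step has no fixed size: the limit of > 10000 nM in this assay, at which 1 of the 3 values shown sits.

On these data alone, whether a carboxylic acid, an amine or a longer chain in place of methoxycarbonyl would leave the read-out as it stands remains open. So does whether the saturated chain alone, with no methoxycarbonyl on it, would do the same.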